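Ethynyl for Ethyl at the Chain End: Cytotoxicity Outlook

This account rests on a few compounds, and the source may have more. Where it says the series, first, only, none or still open, it means among the compounds named here.

Compound 2 `CCCCCCCc1cc2cn([C@H]3C[C@H](O)[C@@H](CO)O3)c(=O)nc2o1` was examined in a functional assay on HEL cells (Homo sapiens) for cytotoxicity, read by microscopy; on this read-out lower numbers stand for higher toxicity in this test and higher numbers for lower toxicity in this test. In this assay compound 2 gives only a limit, > 50000 nM. Its two neighbours are likewise known only as limits. Compound 1 `CCCCCCc1cc2cn([C@H]3C[C@H](O)[C@@H](CO)O3)c(=O)nc2o1` gives in this assay the limit > 50000 nM. Compound 3 `C=CCCCCCCc1cc2cn([C@H]3C[C@H](O)[C@@H](CO)O3)c(=O)nc2o1` gives in this assay the limit > 200000 nM. Compound 2 therefore stands at the limit of > 50000 nM in this assay, at which 2 of the 3 values shown sit, together with compound 1, while compound 3 sits at the limit of > 200000 nM in this assay, at which 1 of the 3 values shown sits. None of the three measured steps can be read: a step that the two limits leave unreadable from compound 1 to compound 2, a step that the two limits leave unreadable from compound 1 to compound 3 and a step that the two limits leave unreadable from compound 2 to compound 3 are all hidden by the limits.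

Compound 4 `C#CCCCCCc1cc2cn([C@H]3C[C@H](O)[C@@H](CO)O3)c(=O)nc2o1` differs from compound 2 by ethynyl in place of ethyl on a saturated chain carbon, five bonds along the chain from an aromatic carbon, so that one triple bond outside aromatic rings enters while the heavy-atom count of the chain is unchanged. For the measured compounds named here, with every measured step unreadable, no direction for the step to compound 4 in this assay can be derived. Compound 4 is expected to stay without measurable toxicity, so the step that the limit leaves unreadable from compound 2 to compound 4 is estimated as none beyond the scatter. For compound 4 the estimate in this assay is 100000 nM, within 50000 nM to 300000 nM, most likely reported again as a limit.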

Compound 4, minimum cytotoxic concentration: > 200000 nM
Compound 4 ended at the assay's limit (the forecaster's own chance of this, stated with the estimate: 90%); middle value at least 2.0-fold (0.30 log units) away from the limit.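

In this assay compound 4 gives only a limit, > 200000 nM. Its steps from compound 1, compound 2 and compound 3 therefore cannot be read. The compounds shown leave open whether any of these chains gives a measurable toxicity in this assay.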